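Formylpiperidine in Place of Ethylpyrrolidine on a Benzamide

The compounds below may be only part of what the source reports. "The series", "measured", "known", "first", "only" and "open" are said of these compounds alone.

Measured compounds:
Compound 1 `CCN(CC1CCCN1C)C(=O)c1cc(OCC(F)(F)F)ccc1OCC(F)(F)F`: 29 umol/kg
Compound 2 `CCN1CCCC1CNC(=O)c1cc(OCC(F)(F)F)ccc1OCC(F)(F)F`: 70 umol/kg

Among the measured compounds shown here, in a functional assay on the whole organism (heart, strain Swiss-Webster) with Mus musculus as the target (on this read-out lower numbers stand for an effect already at smaller amounts and higher numbers for an effect only at larger amounts of compound), compound 2 gives the higher of the two numbers, since a 2.4-fold higher number from compound 1 to compound 2 (0.38 log units; beyond the scatter) is the only step measured. Compound 3 `O=CN1CCCCC1CNC(=O)c1cc(OCC(F)(F)F)ccc1OCC(F)(F)F` is not yet measured; it differs from compound 2 by 1-formylpiperidin-2-yl in place of 1-ethylpyrrolidin-2-yl on a saturated chain carbon bound to an amide-type nitrogen. For the measured compounds named here, no measured step concerns this kind of change: the one known step, from compound 1 to compound 2, alters the substitution on the amide-type nitrogen and the group on the ring nitrogen, and is modest. Going by the values given here, the present change is larger in kind, and nothing among the measured compounds constrains its direction. Compound 3 is therefore expected to give about 100 umol/kg, with a range from 35 umol/kg to 300 umol/kg, which means an expected step of a 1.4-fold higher number from compound 2 to compound 3 (0.15 log units; within the scatter) that need not exceed the scatter.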

Compound 3, dose for half-maximal effect: > 510 umol/kg
Compound 3: a limit, no number; the forecaster's own chance of this, stated with the estimate: 10%; middle value at least 5.1-fold (0.70 log units) away from the limit.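

Compound 3 stands at a limit of this assay, and this is not a number: the limit of > 510 umol/kg in this assay, at which 1 of the 3 values shown sits. At this place, on a saturated chain carbon bound to an amide-type nitrogen, 1-formylpiperidin-2-yl in place of 1-ethylpyrrolidin-2-yl gives an at least 7.2-fold higher number from compound 2 to compound 3 (0.86 log units; beyond the scatter) and so shows that the read-out responds strongly to this change, where the earlier pair held only a modest step. Set against compound 1, the change amounts to an at least 17-fold higher number from compound 1 to compound 3 (1.24 log units; beyond the scatter) and is large, with both steps bounded on one side only.

The ring size and the group on the ring nitrogen change together here, and the compounds shown do not separate the two. A 1-ethylpiperidin-2-yl or a 1-formylpyrrolidin-2-yl group at the same place would tell whether the formyl group or the six-membered ring carries the step.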